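From cyclohexyl to oxan-4-yl on a shared core

The compounds below may be only part of what the source reports. "The series", "measured", "known", "first", "only" and "open" are said of these compounds alone.

Measured so far in a toxicity assay on THP-1 cells (Homo sapiens) for inhibition; on this read-out higher numbers stand for lower toxicity in this test and lower numbers for higher toxicity in this test:
Compound 1 `COc1ccc(-c2cnc(NC(=O)c3ncc[nH]3)n2C)cc1`: > 100000 nM (a limit)
Compound 2 `COc1ccc(-c2cnc(NC(=O)C3CCCCC3)n2C)cc1`: > 100000 nM (a limit)

Compound 2 gives > 100000 nM, which is a limit of this assay and not a number.

The next compound, compound 3 `COc1ccc(-c2cnc(NC(=O)C3CCOCC3)n2C)cc1`, keeps the shared core and changes one group on a carbonyl carbon whose other neighbour is an amide-type nitrogen: oxan-4-yl in place of cyclohexyl on a carbonyl carbon. Oxan-4-yl takes the place of cyclohexyl, so a ring of carbon only gives way to a ring with one hetero atom.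

Among the measured compounds shown here, only one measured step bears on this change, and it sits on the same carbonyl carbon: a step that the two limits leave unreadable from compound 1 to compound 2. Its size cannot be read, so it offers no measured size to carry over. For the measured compounds named here, compound 1 and compound 2 share (the limit of > 100000 nM in this assay, at which 2 of the 2 values shown sit), and that shared limit is the only guide here.

On that basis, no step beyond the scatter is expected in this assay, in either direction, and the expected change is a number no higher from compound 2 to compound 3 (the limit leaves the size open). A report of the limit again is the most likely outcome for compound 3. For compound 3 the estimated value is 100000 nM, with an expected range from 50000 nM to 200000 nM.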

Compound 3, half-maximal cytotoxic concentration: > 100000 nM
Compound 3: only a limit was reported; the forecaster's own chance of this, stated with the estimate: 90%; the middle value sits exactly at the limit.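

No step can be read among compound 1, compound 2 and compound 3, as each result in this assay is a limit of the assay and not a number: the limit of > 100000 nM in this assay, at which 3 of the 3 values shown sit.

From the compounds shown here alone, whether the three groups on the carbonyl carbon differ at all in this assay, and by how much, stays open.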